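Chloro to Methyl in a Small Cytotoxic Series

The source may hold more compounds than are shown below. What is called first, only, known or untested is meant among the compounds shown, and "the series" means these compounds.

Compound 1 `Cc1nc(N2CCCc3cc(Br)ccc32)c2ccccc2n1`: 178 nM
Compound 2 `COc1ccc2c(c1)CCN2c1nc(C)nc2ccccc12`: 320 nM
Compound 3 `COc1ccc2c(c1)CCCCN2c1nc(Cl)nc2ccccc12`: 227 nM

All three compounds were tested in a functional assay on KB cells (Homo sapiens) for cytotoxicity, read by sulforhodamine B assay; on this read-out higher numbers stand for weaker inhibition of growth and lower numbers for stronger inhibition of growth. In this assay, compound 3 gives 227 nM, a value within the scatter of both other compounds, so the three cannot be ranked. Compound 4 `COc1ccc2c(c1)CCCCN2c1nc(C)nc2ccccc12` keeps the structure of compound 3 except for one place. It has methyl in place of chloro on an aromatic carbon, between two ring nitrogen atoms (methyl in place of chloro on an aromatic carbon). For the measured compounds named here, no measured pair of compounds isolates this change, so the data offer no direct precedent. Methyl does stand at that place in compound 1, at 178 nM, and in compound 2, at 320 nM, and both values lie within the scatter of compound 3. No step beyond the scatter is therefore expected in this assay, and the estimated size is a 1.0-fold lower number from compound 3 to compound 4 (0.01 log units; within the scatter). For compound 4, the expected value is 220 nM, with an estimated range of 80 nM to 600 nM.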

Compound 4, concentration for 50% growth inhibition: 19 nM
Compound 4: middle estimate off by 12-fold (1.06 log units), on the high side; measured number below the stated range.
By their numbers in this assay, from the lowest: compound 4; then compounds 1, 3 and 2 (each within the scatter of the next).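

In this assay, for the compounds shown here, methyl in place of chloro on an aromatic carbon, between two ring nitrogen atoms, gives a 12-fold lower number from compound 3 to compound 4 (1.08 log units; beyond the scatter) on the shared core, the first step at this place that lies beyond the scatter. The position therefore responds strongly to the group it carries, even though one heavy atom leaves, one heavy atom enters, and neither group counts a hydrogen-bond donor or acceptor. No measurement offered here accounts for the size of this step. The compounds shown leave open how hydrogen, an amine or an ethyl group would read at this position. They also leave open whether the same exchange of chloro for methyl would give a step of this size on the cores of compound 1 and compound 2.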